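The source may report more compounds than this note shows. Statements on the series, on what has been measured and on what is new or still open speak of the compounds shown alone.

Working notes on the series.

Two compounds of the shared core carry a measured value. Compound 1 `Cc1nc(N2CCC(N3CCCS3(=O)=O)CC2)nc2ccc(NC(=O)/C=C/c3ccc(OC(F)(F)F)cc3)cc12` was tested in an ADME assay on microsomes from liver (Mus musculus) for metabolic stability, with a stated time of 30 min (a lower number here means that less of the compound is left, a higher number that more of the compound is left), and compound 1 gives 83%. Compound 2 `Cc1nc(NCCNC(=O)C2CC2)nc2ccc(NC(=O)/C=C/c3ccc(OC(F)(F)F)cc3)cc12` in this assay gives 38%. On these two numbers compound 1 stands highest; the nearest is compound 2, a number lower by an amount that lies beyond the usual scatter. Among the compounds with values here, the two differ in more than one place, so only their two values are compared, no single step is read from them.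

Compound 3 `Cc1nc(N2CCC(N3CCN(C)C3=O)CC2)nc2ccc(NC(=O)/C=C/c3ccc(OC(F)(F)F)cc3)cc12` has not been measured. It differs from compound 1 in one place: a group of 7 heavy atoms (4 carbon, 2 nitrogen, 1 oxygen; one five-membered non-aromatic ring with 2 hetero atoms) in place of a group of 7 heavy atoms (3 carbon, 1 nitrogen, 2 oxygen, 1 sulfur; one five-membered non-aromatic ring with 2 hetero atoms), on a saturated ring carbon. The remainder of the molecule, including the shared core and the six-membered non-aromatic ring that bears the five-membered ring, is unchanged.

Within the data shown here, no measured pair isolates this change, so the expectation rests on compound 1 alone. The step from compound 1 to compound 3 is expected to be a modest downward one, close to the edge of the scatter, as a number 13 percentage points lower from compound 1 to compound 3 (beyond the scatter). For compound 3 in this assay the estimated value is 70%, with an expected range from 50% to 88%.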

Compound 3, percent of the compound remaining: 94%
Beside the measured number, compound 3's estimate is 24 percentage points below it; measured number outside the range, above it.
By their numbers in this assay, from the lowest: compound 2; then compound 1; then compound 3.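

In this assay, within the data shown here, the replacement of the sulfur-containing five-membered ring by 3-methyl-2-oxoimidazolidin-1-yl gives a number 11 percentage points higher from compound 1 to compound 3 (beyond the scatter), the first step that can be read at one place, here a saturated ring carbon of the six-membered non-aromatic ring with 1 nitrogen. At this position, then, the ring with 2 nitrogen atoms and a single carbonyl keeps the compound's number high, and it does so with the same count of 7 heavy atoms, one double bond outside aromatic rings in place of 2, and one hydrogen-bond acceptor in place of 2. Nothing measured here bears on the reason for this step.

One step at one position cannot say which feature of the entering group carries the change, whether the methyl on its ring nitrogen, the carbonyl or the ring itself, and a free amine, a carboxylic acid or a longer open chain on the same ring carbon remains untested in the compounds shown. The steps from compound 2 to compound 1 and compound 3 cannot be read, as compound 2 differs from both in more than one place.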